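Piperazine amide series: piperidinyl versus dimethylaminoalkyl substituents

The compounds below may be only part of what the source reports. "The series", "measured", "known", "first", "only" and "open" are said of these compounds alone.

Measured compounds:
compound 1 `COc1cc(C)c(S(=O)(=O)N(C)CCOCC(=O)N2CCN(CCN(C)C)CC2)c(C)c1` — 7.4
compound 2 `COc1cc(C)c(S(=O)(=O)N(C)CCOCC(=O)N2CCN(CC3CCN(C)CC3)CC2)c(C)c1` — 8.6
compound 3 `COc1cc(C)c(S(=O)(=O)N(C)CCOCC(=O)N2CCN(CCCN(C)C)CC2)c(C)c1` — 7.9

All three values come from a functional assay on Umbilical vein for antagonist activity at B1 bradykinin receptor (Homo sapiens), using Schild analysis, with a stated time of 30 min; on this read-out higher numbers stand for higher potency (the scale is a negative logarithm) and lower numbers for lower potency. In this assay compound 3 stands second of the three: a number 0.50 log units higher from compound 1 to compound 3 (beyond the scatter), while a number 0.70 log units lower from compound 2 to compound 3 (beyond the scatter). Compound 4 `CCN1CCC(N2CCN(C(=O)COCCN(C)S(=O)(=O)c3c(C)cc(OC)cc3C)CC2)CC1` follows from compound 3 by 1-ethylpiperidin-4-yl in place of 3-(dimethylamino)propyl on an amine nitrogen in a ring. The bearing steps are the large gain a number 1.20 log units higher from compound 1 to compound 2 (beyond the scatter) and the modest loss a number 0.70 log units lower from compound 2 to compound 3 (beyond the scatter), both beyond the scatter, each favouring the piperidinyl group over a dimethylaminoalkyl chain. A modest rise is therefore expected, a number 0.60 log units higher from compound 3 to compound 4 (beyond the scatter), putting compound 4 at an estimated 8.5 in this assay, between 8 and 9.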

Compound 4, negative logarithm of the antagonist equilibrium constant: 8.8
Estimate against measurement, compound 4: 0.30 log units below; the range from low to high includes it.
By their numbers in this assay, from the lowest: compound 1; then compound 3; then compounds 2 and 4 (each within the scatter of the next).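

Notes on the substituent on an amine nitrogen in a ring: in this assay, 1-ethylpiperidin-4-yl outperforms both dimethylaminoalkyl chains, with a number 0.90 log units higher from compound 3 to compound 4 (beyond the scatter) and a number 1.40 log units higher from compound 1 to compound 4 (beyond the scatter). Against (1-methylpiperidin-4-yl)methyl, the change gives a number 0.20 log units higher from compound 2 to compound 4 (within the scatter), so a piperidine ring attached directly and one attached through a methylene cannot be told apart here. No supporting data explain this outcome.

Still open, going by these compounds, is whether the ring nitrogen is needed, as a cyclohexyl group would show. Ethyl and methyl on the piperidine nitrogen also remain unseparated, since compound 2 and compound 4 differ in more than that group.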